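The source may report more compounds than this note shows. Statements on the series, on what has been measured and on what is new or still open speak of the compounds shown alone.

Of the compounds shown here, three have been tested in an ADME assay on J774.1 cells (Mus musculus) for cytotoxicity, with a stated time of 48 h; on this read-out higher numbers stand for an effect only at larger amounts of compound and lower numbers for an effect already at smaller amounts. For the measured compounds named here, compound 1 `COC(=O)C1=C(O)C[C@H](c2ccccn2)N(Cc2ccc(Cl)cc2)[C@@H]1c1ccccn1` gives 32.8 uM in this assay, the only real number among them. Compound 2 `O/N=C/C1CCN(CCCc2ccccc2)CC1` reaches only a limit of the assay, > 100 uM, and not a number. Compound 3 `C=CCN1[C@H](c2ccccn2)C(C(=O)OC)C(=O)C(C(=O)OC)[C@@H]1c1ccccn1` likewise stops at a limit, > 100 uM, so for compound 3 all that is known is this boundary. Going by the values given here, two of the three results thus sit at the same boundary, (the limit of > 100 uM in this assay, at which 2 of the 3 values shown sit), and no step between compounds that differ in a single place is known, so nothing measured tells how a change of one group shifts this read-out.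

Compound 4 `COC(=O)C1C(=O)C(C(=O)OC)[C@H](c2ccccn2)N(CCCCCCCC(=O)O)[C@@H]1c1ccccn1` has not yet been tested. It differs from compound 3 by 6-carboxyhexyl in place of vinyl on a saturated chain carbon bound to an amine nitrogen in a ring. Among the compounds with values here, with compound 3 known only as a limit, the step to compound 4 has no measured counterpart to lean on. The expectation is that it stays within the scatter, with no movement beyond it, and that compound 4 also ends at the boundary rather than at a number. The expected step is a step that the limit leaves unreadable from compound 3 to compound 4. Compound 4 is therefore estimated at 150 uM, within a range from 50 uM to 400 uM.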

Compound 4, concentration for half-maximal effect: 33.8 uM
Beside the measured number, compound 4's estimate is 4.4-fold (0.65 log units) above it; the whole stated range lies above it.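

In this assay, for the compounds shown here, this is the first step at a single place that can be read at all, and it shows that the group on a saturated chain carbon bound to an amine nitrogen in a ring matters for this read-out: with 6-carboxyhexyl in place of vinyl there is an at least 2.9-fold lower number from compound 3 to compound 4 (0.47 log units; beyond the scatter) and the effect now appears at a measurable concentration. Compound 3 gives > 100 uM which is a limit of the assay and not a number. Going by these compounds, the step is therefore a minimum, and its true size stays unknown, although its direction towards smaller amounts of compound is clear: the limit of > 100 uM in this assay, at which 2 of the 4 values shown sit.

The long chain and the carboxylic acid at its end enter together in this one step, so the compounds shown cannot tell which of the two goes with the lower number. A plain alkyl chain of similar length without the acid, a short chain ending in a carboxylic acid, or a chain ending in an amine or a methyl ester would separate these two parts of the change.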